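The source may report more compounds than this note shows. Statements on the series, on what has been measured and on what is new or still open speak of the compounds shown alone.

Measured compounds:
Compound 1, `c1ccc(-c2cn3ccnc3c(-c3ccc4ncn(C5CCCCC5)c4c3)n2)cc1`, gives 55.2% in a functional assay on UO-31 cells (Homo sapiens) for inhibition, read by sulforhodamine B assay, with a stated time of 48 h, tested at 10 uM; a higher number here means more inhibition at the concentration tested (going by the name of the read-out), a lower number less inhibition.
Compound 2, `c1cn2cc(-c3ccsc3)nc(-c3ccc4ncn(C5CCCCC5)c4c3)c2n1`, gives 23.1% in this assay.
Compound 3, `CC(=O)c1ccc(-c2cn3ccnc3c(-c3ccc4ncn(C5CCCCC5)c4c3)n2)cc1`, gives 23.1% in this assay.

Compound 3 is level with compound 2 at the digits shown, the two together the lowest of the three numbers; compound 1 stands well above them, as a number 32.1 percentage points lower from compound 1 to compound 3 (beyond the scatter) shows. The unmeasured compound 4, `Brc1ccc(-c2cn3ccnc3c(-c3ccc4ncn(C5CCCCC5)c4c3)n2)cc1`, differs from compound 3 in one place: bromo in place of acetyl on an aromatic carbon.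

Among the measured compounds shown here, two measured steps bear on this. The step of a number 32.1 percentage points lower from compound 1 to compound 3 (beyond the scatter) shows that putting acetyl on the phenyl ring in place of hydrogen lowered the reading by a large amount, so removing the acetyl again might recover some of that. The step of no change at the digits printed from compound 2 to compound 3 (within the scatter) shows no difference between the two lowest compounds. For the measured compounds named here, no measured compound carries bromo, so how bromo compares with hydrogen at this place is unknown. A moderate rise is therefore expected, short of compound 1, with wide uncertainty.

Compound 4 is estimated at 38%, between 15% and 62%, an expected step of a number 14.9 percentage points higher from compound 3 to compound 4 (beyond the scatter).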

Compound 4, a percentage reported as inhibition, at one concentration (the size of the read-out at that concentration, not a potency): 42.9%
Compound 4: middle estimate off by 4.9 percentage points, on the low side; the range from low to high includes it.
By their numbers in this assay, from the lowest: compounds 2 and 3 (each within the scatter of the next); then compound 4; then compound 1.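

This place on the six-membered aromatic ring does not respond to every added group in the same way: bromo and acetyl, both sitting where compound 1 has hydrogen, give clearly different readings (a number 19.8 percentage points higher from compound 3 to compound 4 (beyond the scatter)). Bromo still costs some inhibition relative to hydrogen (a number 12.3 percentage points lower from compound 1 to compound 4 (beyond the scatter)), so the 4-bromophenyl compound falls in the middle of the series, and it also reads above the thiophen-3-yl compound (a number 19.8 percentage points higher from compound 2 to compound 4 (beyond the scatter)). No measurement on hand explains why these groups differ.

Neither substituent on the phenyl ring reads above the unsubstituted compound 1, but two groups cannot show whether that holds generally. On these data alone, how an amine, a carboxylic acid or a methoxy group would read at this place remains open.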